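The compounds below may be only part of what the source reports. "The series", "measured", "known", "first", "only" and "open" are said of these compounds alone.

Measured so far in a functional assay on HeLa cells (Homo sapiens) for cytotoxicity, read by MTT assay, with a stated time of 48 h; a lower number here means a stronger inhibitor, a higher number a weaker inhibitor:
- compound 1 `CC1(C)CCC[C@]2(C)[C@@H](CC[C@@](C)(O)/C=C/c3ccccc3)[C@](C)(O)CC[C@@H]12` at 3320 nM
- compound 2 `COc1cccc(OC)c1/C=C/[C@](C)(O)CC[C@@H]1[C@@]2(C)CCCC(C)(C)[C@@H]2CC[C@@]1(C)O` at 48200 nM
- compound 3 `Cc1cccc(/C=C/[C@](C)(O)CC[C@@H]2[C@@]3(C)CCCC(C)(C)[C@@H]3CC[C@@]2(C)O)c1C` at 3700 nM

Compound 3 belongs to the low pair of numbers, with compound 2 alone at the high end. Next is compound 4 `COc1cccc(/C=C/[C@](C)(O)CC[C@@H]2[C@@]3(C)CCCC(C)(C)[C@@H]3CC[C@@]2(C)O)c1OC`, and the change is as follows (2,3-dimethoxyphenyl in place of 2,3-dimethylphenyl on a double-bonded chain carbon bound to a double-bonded chain carbon). Two large steps bear on it (a 15-fold higher number from compound 1 to compound 2 (1.16 log units; beyond the scatter) and a 13-fold lower number from compound 2 to compound 3 (1.11 log units; beyond the scatter)), both involving 2,6-dimethoxyphenyl. The step to 2,3-dimethylphenyl stays within the scatter (a 1.1-fold higher number from compound 1 to compound 3 (0.05 log units; within the scatter)). No 2,3-dimethoxyphenyl compound has a measurement yet, so only part of those large steps is carried over. A move to a higher number in this assay is expected, smaller than those two steps, and the estimated step is moderate (a 2.7-fold higher number from compound 3 to compound 4 (0.43 log units; beyond the scatter)). The estimated value for compound 4 is about 10000 nM (expected range 3000 nM to 35000 nM).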

Compound 4, half-maximal inhibitory concentration: 3880 nM
Compound 4: middle estimate off by 2.6-fold (0.41 log units), on the high side, within the range that was stated.
By their numbers in this assay, from the lowest: compounds 1, 3 and 4 (each within the scatter of the next); then compound 2.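

In this assay, 2,3-dimethoxyphenyl on this double-bonded chain carbon stays within the scatter of both 2,3-dimethylphenyl (a 1.0-fold higher number from compound 3 to compound 4 (0.02 log units; within the scatter)) and phenyl (a 1.2-fold higher number from compound 1 to compound 4 (0.07 log units; within the scatter)), so methoxy groups on the ring do not by themselves go with the high number of compound 2. The two dimethoxyphenyl isomers differ widely (a 12-fold lower number from compound 2 to compound 4 (1.09 log units; beyond the scatter)), which ties that high number to the 2,6-dimethoxyphenyl arrangement in this set. No measurement here accounts for that difference.

From the compounds shown here alone, whether 2,6-dimethylphenyl would also give a high number remains open, as does the effect of an amine or a carboxylic acid on the ring.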